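Chloro to methyl in the fluoro series

This account rests on a few compounds, and the source may have more. Where it says the series, first, only, none or still open, it means among the compounds named here.

In a functional assay on IGROV-1 cells (Homo sapiens) for inhibition (on this read-out higher numbers stand for weaker inhibition of growth and lower numbers for stronger inhibition of growth), the measured compounds spread widely. Compound 2 (`Nc1ccc(-c2nc3ccc(F)cc3s2)cc1Cl`) gives < 10 nM, which is a limit of the assay and not a number. Compound 2 therefore stands at the limit of < 10 nM in this assay, at which 1 of the 3 values shown sits, and its true position is not known. Compound 1 (`Cc1cc(-c2nc3c(F)cccc3s2)ccc1N`) gives 22900 nM, while compound 3 (`Cc1cc(-c2nc3cccc(F)c3s2)ccc1N`) gives 70 nM. Both carry a methyl group, and their two values lie far apart, so the presence of methyl alone does not fix the read-out in this small set.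

Compound 4 (`Cc1cc(-c2nc3ccc(F)cc3s2)ccc1N`) has methyl in place of chloro on an aromatic carbon, ortho to an amino group (methyl in place of chloro on an aromatic carbon). Among the compounds with values here, no measured pair shows this exchange on its own, so any expectation is loose. A modest move toward weaker inhibition of growth is expected, with an at least 2.5-fold higher number from compound 2 to compound 4 (0.39 log units; beyond the scatter) as the estimated step, and a result within the scatter would be no surprise. From the compounds shown here alone, the upper side of the range stays open in view of compound 3 at 70 nM, and of compound 1 at 22900 nM as a warning of how far a methyl compound can fall. The estimate for compound 4 is 25 nM, with an expected range of 5 nM to 300 nM.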

Compound 4, concentration for 50% growth inhibition: 1300 nM
Compound 4: the middle estimate sits 52-fold (1.72 log units) below what was measured; measured number above the stated range.
By their numbers in this assay, from the lowest: compound 3; then compound 4; then compound 1. At a limit, below all of these: compound 2.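

In this assay, methyl in place of chloro on an aromatic carbon, ortho to an amino group, gives an at least 130-fold higher number from compound 2 to compound 4 (2.11 log units; beyond the scatter), so at this position the exchange is far from neutral for inhibition of growth. The value of compound 2 is a limit of the assay and not a number, and the step carries that limit with it: the limit of < 10 nM in this assay, at which 1 of the 4 values shown sits. The earlier methyl compounds could not show this, since compound 1 and compound 3 both carry methyl and differ from each other only in where the fluoro sits, whereas this pair ties a large step to the chloro and methyl exchange alone, with the fluoro held in place.

From the compounds shown here alone, whether the step is particular to methyl or reflects the departure of chloro stays open, and a bromo, methoxy or trifluoromethyl group on the same carbon would help separate the two readings. Going by these compounds, whether the exchange gives a step of similar size with the fluoro placed elsewhere also stays open, and that reading would need a chloro partner of compound 1 or of compound 3.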